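The source may hold more compounds than are shown below. What is called first, only, known or untested is meant among the compounds shown, and "the series" means these compounds.

Measured so far:
- compound 1, `CCOC(=O)N1CCC(NS(=O)(=O)c2ccc(C(=O)Nc3ccccc3C)c3ccccc23)CC1`; in an assay on L1.2 cells for binding affinity to C-C chemokine receptor type 8 (Homo sapiens) (on this read-out lower numbers stand for stronger inhibition and higher numbers for weaker inhibition), compound 1 gives 5.21 nM
- compound 2, `COCC(=O)N1CCC(NS(=O)(=O)c2ccc(NC(=O)c3ccccc3C)c3ccccc23)CC1`; in this assay compound 2 gives 15.8 nM

Compound 2 holds the higher of the two numbers recorded in this assay; its nearest neighbour is compound 1, whose value lies lower by a margin beyond the usual scatter. Among the compounds with values here, compounds 1 and 2 differ in more than one place, so no single step connects them, and only the two numbers themselves can be set side by side.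

Compound 3, `Cc1ccccc1C(=O)Nc1ccc(S(=O)(=O)NC2CCN(C(=O)C3CNC3)CC2)c2ccccc12`, is the next candidate. It differs from compound 2 in one place: azetidin-3-yl in place of methoxymethyl on a carbonyl carbon. Within the data shown here, no measured pair in this set isolates that change, so the data give no direction for it. The working expectation is a change of small size, not clearly beyond the scatter either way: a 1.3-fold lower number from compound 2 to compound 3 (0.12 log units; within the scatter) is the estimated step. Compound 3 is accordingly estimated at 12 nM, with a range from 4 nM to 40 nM, to be confirmed by measurement.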

Compound 3, inhibition constant: 1.5 nM
The estimate for compound 3 lay 8.0-fold (0.90 log units) above the measured number; the whole stated range lies above it.
By their numbers in this assay, from the lowest: compound 3; then compound 1; then compound 2.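

On the carbonyl carbon whose other neighbour is the amide-type nitrogen in a ring, azetidin-3-yl in place of methoxymethyl gives an 11-fold lower number from compound 2 to compound 3 (1.02 log units; beyond the scatter) in this assay, so this position responds strongly to the group it carries. The change replaces an open chain with no ring and no hydrogen-bond donor by a four-membered non-aromatic ring with one hetero atom and one hydrogen-bond donor, and this single step cannot show which of these differences accounts for the result. No measurement in hand bears on why the step is this large.

From the compounds shown here alone, how a cyclobutyl group, which keeps the four-membered ring but has only carbon atoms in it, or an open aminomethyl chain, which keeps the nitrogen but has no ring, would read on this carbonyl carbon remains open, so the contributions of the ring and the nitrogen are still unseparated. Also open, going by these compounds, is whether azetidin-3-yl on this carbonyl carbon would give a step of similar size in a compound with the amide linkage of compound 1.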